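The source may hold more compounds than are shown below. What is called first, only, known or untested is meant among the compounds shown, and "the series" means these compounds.

For the measured compounds named here, in a functional assay on RAW264.7 cells (Mus musculus) for inhibition, with a stated time of 30 min (on this read-out lower numbers stand for stronger inhibition and higher numbers for weaker inhibition), compound 1 `C=C1C(=O)OC[C@H]1CCOC(=O)Nc1ccc(Cl)cc1` gives 390 nM and holds the lower of the two numbers so far, a gap beyond the scatter from compound 2 `C=C1C(=O)OC[C@H]1CCOC(=O)Nc1c(C)cccc1C(C)C`, which also carries isopropyl and gives 1940 nM (the higher number). Compound 3 `C=C1C(=O)OC[C@H]1CCOC(=O)Nc1ccc(C(C)C)cc1` has isopropyl in place of chloro on an aromatic carbon, para to a large group (isopropyl in place of chloro on an aromatic carbon). Going by the values given here, no single-change step has been measured, so the only guide is compound 2 at 1940 nM and a moderate rise in the number, meaning weaker inhibition in this assay, is expected. The estimated step is moderate (a 1.9-fold higher number from compound 1 to compound 3 (0.28 log units; within the scatter)). The estimate for compound 3 is 750 nM (expected range 280 nM to 2000 nM).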

Compound 3, half-maximal inhibitory concentration: 340 nM
For compound 3 the middle estimate is 2.2-fold (0.34 log units) above the measured one, within the range that was stated.
By their numbers in this assay, from the lowest: compounds 3 and 1 (each within the scatter of the next); then compound 2.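

In this assay, for the compounds shown here, the step of a 1.1-fold lower number from compound 1 to compound 3 (0.06 log units; within the scatter) is the first single-change comparison at this position, and it lies within the scatter. On this aromatic carbon, para to a large group, chloro with 1 heavy atom and isopropyl with 3 heavy atoms therefore give results that cannot be told apart. On these data alone, whether an amine or a carboxylic acid on the same carbon would give a similar result remains open, as does the effect of a longer chain. No measured evidence here explains why chloro and isopropyl give such similar results.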